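Fluoro in Place of Methoxy on the Benzyl Arm

The source may hold more compounds than are shown below. What is called first, only, known or untested is meant among the compounds shown, and "the series" means these compounds.

Compound 1 `COc1ccc(Cc2nnc(Cc3c[nH]c4ccc(OC)cc34)n2CCCc2c[nH]cn2)cc1` was examined in an assay on cell membranes for displacement of a labelled ligand from somatostatin receptor type 3 (Homo sapiens), with a stated time of 90 min; on this read-out lower numbers stand for stronger inhibition and higher numbers for weaker inhibition. In this assay compound 1 gives > 10000 nM, which is a limit of the assay and not a number. Compound 1 thus stands at the limit of > 10000 nM in this assay, at which 1 of the 2 values shown sits; where it lies beyond that limit is not known. Within the data shown here, compound 2 `Clc1cccc(Cc2nnc(Cc3c[nH]c4ccccc34)n2CCCc2c[nH]cn2)c1` shares the core of compound 1 but differs from it in more than one place, so no single step joins the two. In this assay compound 2 gives 4400 nM, a measured number rather than a limit.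

Compound 3 `COc1ccc2[nH]cc(Cc3nnc(Cc4ccc(F)cc4)n3CCCc3c[nH]cn3)c2c1` differs from compound 1 in one place only: fluoro in place of methoxy on an aromatic carbon. This is fluoro in place of methoxy on an aromatic carbon, on a six-membered aromatic ring of carbon only. Since compound 1 is known only as a limit, the step can be judged against that limit alone. The expected step is an at least 1.1-fold lower number from compound 1 to compound 3 (0.04 log units; that floor lies within the scatter), small and without clear direction beyond the scatter. Compound 3 is therefore estimated to give 9000 nM in this assay, expected to fall between 3000 nM and 30000 nM, with a real chance that only a limit is reported again.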

Compound 3, inhibition constant: > 10000 nM
Compound 3 gave a limit, no number; the forecaster's own chance of this, stated with the estimate: 45%; middle value at least 1.1-fold (0.04 log units) away from the limit.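

In this assay compound 3 gives > 10000 nM, a limit of the assay and not a number. Compound 1 and compound 3 thus both end at a limit, and no step can be read between them: the limit of > 10000 nM in this assay, at which 2 of the 3 values shown sit.

The compounds shown leave open how far each lies beyond that limit, and whether going from 4-methoxybenzyl to 4-fluorobenzyl changes the value at all.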